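A few compounds are considered here, and "the series" means these few. Any claim that something is new, unique, unknown or untested is made for them only; others in the source may bear on it.

Measured compounds:
compound 1 `COc1cc(-c2nnc(SCC(=O)c3ccccc3)n2N)cc(OC)c1OC`: 53000 nM
compound 2 `COc1cc(-c2nnc(SCC(=O)c3ccc(Cl)cc3)n2N)cc(OC)c1OC`: 7500 nM
compound 3 `COc1cc(-c2nnc(SCC(=O)c3ccccc3F)n2N)cc(OC)c1OC`: 10800 nM

In a functional assay on HCT-116 cells (Homo sapiens) for antiproliferative activity, read by MTT assay, with a stated time of 48 h (a lower number here means a stronger inhibitor, a higher number a weaker inhibitor), compound 2 gives the lowest of the three numbers. The step of a 1.4-fold higher number from compound 2 to compound 3 (0.16 log units; within the scatter) is within the scatter, so compound 2 and compound 3 cannot be ordered, while a 7.1-fold lower number from compound 1 to compound 2 (0.85 log units; beyond the scatter) and a 4.9-fold lower number from compound 1 to compound 3 (0.69 log units; beyond the scatter) are both beyond it. Compound 4 `COc1cc(-c2nnc(SCC(=O)Nc3ccccc3C)n2N)cc(OC)c1OC` differs from compound 2 by (2-methylphenyl)amino in place of 4-chlorophenyl on a carbonyl carbon. For the measured compounds named here, no measured step touches the carbonyl side of this change; the two known steps show only that a halogen on the aromatic ring lowers the number, and compound 4 carries none. A move back toward the number of compound 1 is therefore expected, a 2.4-fold higher number from compound 2 to compound 4 (0.38 log units; beyond the scatter), with wide uncertainty. For compound 4 the estimate in this assay is 18000 nM, expected between 4500 nM and 70000 nM.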

Compound 4, half-maximal inhibitory concentration: > 100000 nM
Compound 4: no number, only a limit; the forecaster's own chance of this, stated with the estimate: 5%; at least 5.5-fold (0.74 log units) between middle value and limit.
By their numbers in this assay, from the lowest: compounds 2 and 3 (each within the scatter of the next); then compound 1. At a limit, above all of these: compound 4.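

In this assay compound 4 gives only a limit, not a number: the limit of > 100000 nM in this assay, at which 1 of the 4 values shown sits. The earlier compounds shown here varied only the halogen on the ring, whereas this change at the carbonyl carbon gives an at least 13-fold higher number from compound 2 to compound 4 (1.12 log units; beyond the scatter) and an at least 9.2-fold higher number from compound 3 to compound 4 (0.96 log units; beyond the scatter), so the carbonyl side matters far more than those steps could show. Against the unhalogenated compound, the reading is an at least 1.8-fold higher number from compound 1 to compound 4 (0.27 log units; that floor lies within the scatter), whose floor does not separate the two.

Going by these compounds, what stays open is whether the amino link or the 2-methylphenyl ring carries this loss, as compound 4 changes both at once. A phenylamino or (4-chlorophenyl)amino group on that carbonyl carbon would separate the two.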